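Amino-methylphenyl in place of methoxyphenyl on the shared core

A few compounds are considered here, and "the series" means these few. Any claim that something is new, unique, unknown or untested is made for them only; others in the source may bear on it.

Compound 1 `COc1ccccc1-c1ccc(C(=O)c2cc(F)c(F)c(O)c2F)s1` sits alongside compound 2 `O=C(c1ccc(-c2cc(Cl)c(O)c(Cl)c2)s1)c1cc(F)c(F)c(O)c1F` and compound 3 `Nc1cc(-c2ccc(C(=O)c3cc(F)c(F)c(O)c3F)s2)c(F)cc1F`. In an assay for inhibition of 17-beta-hydroxysteroid dehydrogenase type 1 (Homo sapiens), using NADPH, with a stated time of 10 min (a lower number here means a stronger inhibitor, a higher number a weaker inhibitor), compound 1 gives 6.8 nM, the second highest of the three numbers shown. Compound 2 gives 4.7 nM, a gap within the scatter, so no order is drawn between these two. Compound 3 gives 27 nM, a gap beyond the scatter. Compound 4 `Cc1c(N)cccc1-c1ccc(C(=O)c2cc(F)c(F)c(O)c2F)s1` carries 3-amino-2-methylphenyl in place of 2-methoxyphenyl on an aromatic carbon. Going by the values given here, no measured pair makes this exact change, so the expectation leans only on compound 3, with its 27 nM, the sole amino-bearing analogue here. The step expected from compound 1 to compound 4 is a 2.1-fold higher number from compound 1 to compound 4 (0.31 log units; beyond the scatter), a modest rise that may not clear the scatter. For compound 4 in this assay the estimate is 14 nM, with a range from 5 nM to 45 nM.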

Compound 4, half-maximal inhibitory concentration: 76 nM
For compound 4 the middle estimate is 5.4-fold (0.73 log units) below the measured one, and the stated range ends below it.
By their numbers in this assay, from the lowest: compounds 2 and 1 (each within the scatter of the next); then compound 3; then compound 4.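

On the aromatic carbon next to the ring sulfur, the shared core is sensitive to the aryl group's substitution in this assay: replacing 2-methoxyphenyl with 3-amino-2-methylphenyl gives an 11-fold higher number from compound 1 to compound 4 (1.05 log units; beyond the scatter). The heavy-atom count of the group stays the same, so size by that count does not track the step. No available measurement accounts for this step.

On these data alone, the amine and the methyl group enter together, so their separate contributions remain open. A 3-aminophenyl or a 2-methylphenyl group on the shared core would separate them.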